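This account rests on a few compounds, and the source may have more. Where it says the series, first, only, none or still open, it means among the compounds named here.

Working notes on the series

Compound 2 `Cc1cc(Oc2ccccc2)c(S(C)(=O)=O)cc1C(=O)N=C(N)N` gives 10 nM in a functional assay for inhibition of sodium/hydrogen exchanger (Oryctolagus cuniculus); on this read-out lower numbers stand for stronger inhibition and higher numbers for weaker inhibition. Among the two numbers measured so far, this is the lowest; the nearest neighbour is compound 1 `Cc1cc(Sc2ccncc2)c(S(C)(=O)=O)cc1C(=O)N=C(N)N`, which gives 13 nM in the same assay. Going by the values given here, the only measured step, a 1.3-fold lower number from compound 1 to compound 2 (0.11 log units; within the scatter), comes from exchanging the aryl group on the linking atom, namely phenoxy in place of (pyridin-4-yl)sulfanyl on an aromatic carbon, and it stays within the scatter.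

The next compound, compound 3 `Cc1cc(Oc2cncc(Cl)c2)c(S(C)(=O)=O)cc1C(=O)N=C(N)N`, differs from compound 2 at the same region: 5-chloropyridin-3-yl in place of phenyl on an oxygen on an aromatic ring, which cut one bond further out reads phenoxy to (5-chloropyridin-3-yl)oxy. Among the compounds with values here, the one measured step bearing on this, the one from compound 1 to compound 2, replaced one six-membered aromatic ring with another at this position and produced no change beyond the scatter. Within the data shown here, no measured step speaks to a chlorine on that ring, so that part of the change is unsupported by data.

For compound 3 the expected step is therefore a 1.2-fold higher number from compound 2 to compound 3 (0.08 log units; within the scatter), nothing beyond the scatter. The estimate for compound 3 in this assay is 12 nM, with a range from 4 nM to 35 nM.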

Compound 3, half-maximal inhibitory concentration: 14 nM
For compound 3 the middle estimate is 1.2-fold (0.07 log units) below the measured one; low and high end bracket the measured number.
By their numbers in this assay, from the lowest: compounds 2, 1 and 3 (each within the scatter of the next).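

In this assay the exchange of phenyl for 5-chloropyridin-3-yl on the oxygen gives a 1.4-fold higher number from compound 2 to compound 3 (0.15 log units; within the scatter) and so shows that a ring nitrogen and a chlorine can enter this aryl group together without a step beyond the scatter. The comparison across the linking atom gives a 1.1-fold higher number from compound 1 to compound 3 (0.03 log units; within the scatter) and shows that (5-chloropyridin-3-yl)oxy and (pyridin-4-yl)sulfanyl on the aromatic carbon also lie within the scatter of each other, so that compounds 1, 2 and 3 do not separate in this assay. The chlorine, for which the earlier compounds offered no measured step, now appears on this ring for the first time, but it enters with the ring nitrogen, and the compounds shown do not divide the small step between the two.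

No measurement is available that explains why these three numbers lie so close together.

Still open, on these data alone, is the effect of chlorine alone on a phenyl ring, and whether the numbers remain this close when an amine, a carboxylic acid or a longer alkyl chain takes the place of the aryl group on the oxygen.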